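A few compounds are considered here, and "the series" means these few. Any claim that something is new, unique, unknown or untested is made for them only; others in the source may bear on it.

For the measured compounds named here, compound 2 `CC(=O)c1ccc(-c2cn3ccnc3c(-c3ccc4ncn(C5CCCCC5)c4c3)n2)cc1` gives 9.2% in a functional assay on HT-29 cells (Homo sapiens) for inhibition, read by sulforhodamine B assay, with a stated time of 48 h, tested at 10 uM (on this read-out higher numbers stand for more inhibition at the one concentration tested (going by the name of the read-out) and lower numbers for less inhibition), the lowest of the two numbers known, the other being compound 1 `COc1ccc(-c2cn3ccnc3c(-c3ccc4ncn(C5CCCCC5)c4c3)n2)cc1` with 92.5%. Going by the values given here, the one measured step bears directly on the same position: a number 83.3 percentage points lower from compound 1 to compound 2 (beyond the scatter). Compound 3 `Fc1ccccc1-c1cn2ccnc2c(-c2ccc3ncn(C4CCCCC4)c3c2)n1` differs from compound 2 by 2-fluorophenyl in place of 4-acetylphenyl on an aromatic carbon. Among the compounds with values here, since the acetyl that accompanied the low number leaves, a rise is plausible, but no measured compound carries a fluorophenyl there, so the direction rests on one step. Compound 3 is therefore expected to show a number 40.8 percentage points higher from compound 2 to compound 3 (beyond the scatter), with an estimated 50% between 10% and 90%.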

Compound 3, a percentage reported as inhibition, at one concentration (the size of the read-out at that concentration, not a potency): 7.26%
For compound 3 the middle estimate is 42.7 percentage points above the measured one, and the stated range ends above it.
By their numbers in this assay, from the lowest: compounds 3 and 2 (each within the scatter of the next); then compound 1.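

Swapping the 4-acetylphenyl for 2-fluorophenyl gives a number 1.9 percentage points lower from compound 2 to compound 3 (within the scatter) in this assay, so the low number at this position is not tied to the acetyl alone. The step of a number 85.2 percentage points lower from compound 1 to compound 3 (beyond the scatter) shows that an aryl group here does not in itself carry the high number, which among these three compounds goes only with the 4-methoxyphenyl of compound 1. Nothing available explains this difference.

On these data alone, it remains open whether a 4-ethoxyphenyl or 4-aminophenyl group would keep the number of compound 1. As far as these compounds go, an unsubstituted phenyl group remains equally open.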